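The source may hold more compounds than are shown below. What is called first, only, known or untested is meant among the compounds shown, and "the series" means these compounds.

Going by the values given here, compound 2 `CN(C)CCn1cnnc1-c1cc(Oc2ccc(NC(=O)N/N=C/c3c(Cl)cccc3Cl)cc2F)ccn1` holds the highest of the two numbers so far in a functional assay on A549 cells (Homo sapiens) for cytotoxicity, read by MTT assay, with a stated time of 72 h (a lower number here means a stronger inhibitor, a higher number a weaker inhibitor), where compound 2 gives 1410 nM; compound 1 `CN(C)CCn1cnnc1-c1cc(Oc2ccc(NC(=O)N/N=C/c3ccc(Cl)cc3Cl)cc2F)ccn1` gives 810 nM, and the two are separated by a 1.7-fold higher number from compound 1 to compound 2 (0.24 log units; within the scatter). Compound 3 `CN(C)CCn1cnnc1-c1cc(Oc2ccc(NC(=O)N/N=C/c3c[nH]c4ccccc34)cc2F)ccn1` differs from compound 2 by 1H-indol-3-yl in place of 2,6-dichlorophenyl on a carbon with a double bond to nitrogen. Among the compounds with values here, the only measured step changed just where the chlorines sit on the same ring, a smaller change than swapping the whole ring, so it offers little guidance. The expected step in this assay is a 1.1-fold higher number from compound 2 to compound 3 (0.03 log units; within the scatter), essentially none beyond the scatter. Compound 3 is estimated at 1500 nM, between 400 nM and 6000 nM.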

Compound 3, half-maximal inhibitory concentration: 820 nM
The estimate for compound 3 lay 1.8-fold (0.26 log units) above the measured number; the range from low to high includes it.
By their numbers in this assay, from the lowest: compounds 1, 3 and 2 (each within the scatter of the next).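

At the carbon with a double bond to nitrogen, replacing the whole ring still leaves the number within the scatter in this assay: 1H-indol-3-yl in place of 2,6-dichlorophenyl gives a 1.7-fold lower number from compound 2 to compound 3 (0.24 log units; within the scatter) and in place of 2,4-dichlorophenyl gives a 1.0-fold higher number from compound 1 to compound 3 (0.01 log units; within the scatter) as the result. So this position accepts more than a shift of chlorines on one ring, at least among these three compounds. No measurement is available to explain this.

From the compounds shown here alone, whether a carboxylic acid or an amine on a ring at this carbon would shift the number remains open.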